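Compound 1 to compound 4: an expected modest rise

This account rests on a few compounds, and the source may have more. Where it says the series, first, only, none or still open, it means among the compounds named here.

In a physicochemical assay for metabolic stability, read by HPLC, in phosphate buffer, at pH 7.4, tested at 10 uM (a lower number here means that the compound disappears faster, a higher number that the compound lasts longer), compound 1 `O=C(NCCCCc1ccccc1)n1c(=O)oc2ccccc21` gives 0.75 h and stands lowest of the three measured compounds. Compound 2 `O=C(c1ccccc1)c1ccc2c(c1)oc(=O)n2C(=O)NCCCCc1ccccc1` gives 1.63 h and compound 3 `COc1ccc(-c2ccc3c(c2)oc(=O)n3C(=O)NCCCCc2ccccc2)cc1` gives 2.2 h in the same test.

Compound 4 `COc1ccc(-c2ccc3oc(=O)n(C(=O)NCCCCc4ccccc4)c3c2)cc1` has not been measured yet. Its change from compound 1 is 4-methoxyphenyl in place of hydrogen on an aromatic carbon (4-methoxyphenyl in place of hydrogen on an aromatic carbon, meta to a fused ring and para to a fused ring).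

Among the compounds with values here, the closest precedent is a 2.9-fold higher number from compound 1 to compound 3 (0.47 log units; beyond the scatter) (the same group entering at another aromatic carbon of the shared core). Benzoyl in place of hydrogen gives a 2.2-fold higher number from compound 1 to compound 2 (0.34 log units; beyond the scatter) and so points the same way. Between those two substituted compounds the data show a 1.3-fold higher number from compound 2 to compound 3 (0.13 log units; within the scatter) and the two groups cannot be told apart here. Within the data shown here, no measured compound carries a group at the carbon substituted in compound 4, so the precedent transfers only loosely and the range has to stay wide.

A modest upward step is therefore expected, of about the size of those two steps. The estimate in this assay is a 2.5-fold higher number from compound 1 to compound 4 (0.40 log units; beyond the scatter) as the expected step. For compound 4 the estimated half-life is 1.9 h with an expected range from 1 h to 3.6 h in this test.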

Compound 4, half-life: 2.93 h
Estimate against measurement, compound 4: 1.5-fold (0.19 log units) below; the measured number falls inside the stated range.
By their numbers in this assay, from the lowest: compound 1; then compounds 2, 3 and 4 (each within the scatter of the next).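

The carbon meta to a fused ring and para to a fused ring now has a measured step of its own: in this assay, placing 4-methoxyphenyl there gives a 3.9-fold higher number from compound 1 to compound 4 (0.59 log units; beyond the scatter) and the step is modest. Compound 3 gives 2.2 h and compound 4 gives 2.93 h, values within the scatter of each other, so the same group at these two aromatic carbons of the shared core cannot be told apart in this test. With compounds 2, 3 and 4 all beyond the scatter of compound 1, each of the three substituted compounds lasts longer than the unsubstituted core, and this holds for both carbons tested, although no measurement here accounts for the rise at this carbon.

Still open, from the compounds shown here alone, is whether the rise depends on the 4-methoxyphenyl group itself or would also appear with a different group at this carbon, such as an amine, a carboxylic acid or an unsubstituted phenyl. Also open, going by these compounds, is whether the same step would hold with a longer or shorter chain in place of the phenylbutyl chain on the urea nitrogen.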